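This account rests on a few compounds, and the source may have more. Where it says the series, first, only, none or still open, it means among the compounds named here.

Measured so far in an ADME assay on L02 cells (Homo sapiens) for inhibition, read by CCK-8 assay, with a stated time of 48 h; on this read-out higher numbers stand for weaker inhibition of growth and lower numbers for stronger inhibition of growth:

- compound 1 `Cc1ccccc1Nc1nc(Nc2ccccn2)ncc1Cl`: 6150 nM
- compound 2 `Cc1ccccc1Nc1nc(Nc2cc(Cl)ccn2)ncc1Cl`: 41500 nM

Compound 1 has the lower of these two numbers, so it holds back the growth of these cells more strongly. For the measured compounds named here, the only measured step away from it is a 6.7-fold higher number from compound 1 to compound 2 (0.83 log units; beyond the scatter).

Compound 3 `Cc1ccccc1Nc1nc(Nc2ccc(N3CCCCC3)cn2)ncc1Cl` has not yet been measured. It keeps the core of compound 1 but has piperidin-1-yl in place of hydrogen on an aromatic carbon, two atoms from the ring nitrogen and para to a large group: piperidin-1-yl in place of hydrogen on an aromatic carbon.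

Going by the values given here, one measured step bears on this change, since compound 2 also replaces a hydrogen on an aromatic carbon of compound 1, and that gave a 6.7-fold higher number from compound 1 to compound 2 (0.83 log units; beyond the scatter). The entering group is a different one, however, so this single step is only a weak guide to direction and size. A modest rise in the number is therefore expected, though a fall cannot be ruled out.

The estimate is a 1.8-fold higher number from compound 1 to compound 3 (0.25 log units; within the scatter). For compound 3 the expected value is 11000 nM, with an estimated range from 3000 nM to 40000 nM.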

Compound 3, concentration for 50% growth inhibition: 42400 nM
Compound 3: the middle estimate sits 3.9-fold (0.59 log units) below what was measured; measured number above the stated range.
By their numbers in this assay, from the lowest: compound 1; then compounds 2 and 3 (each within the scatter of the next).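

In this assay, placing piperidin-1-yl on the aromatic carbon two atoms from the ring nitrogen and para to a large group gives a 6.9-fold higher number from compound 1 to compound 3 (0.84 log units; beyond the scatter), so a substituent at this carbon is now seen to weaken inhibition of growth. Together with the chloro step, this makes two replacements of a hydrogen on an aromatic carbon of compound 1, and both raise the number beyond the scatter; neither of the two goes against this direction, although two steps are too few to establish a rule for the ring. The data offer no measured explanation for why piperidin-1-yl has this effect.

On these data alone, it remains open whether the rise depends on the whole piperidin-1-yl ring or would also appear with a much smaller group at the same carbon, such as a methyl or a fluorine atom. An open-chain amine such as dimethylamino, or a morpholine ring, could show whether the ring itself or its nitrogen attached to the aromatic carbon goes with the higher number.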